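Compound 3 to Compound 4: An Expected Antiproliferative Read-Out

The source may report more compounds than this note shows. Statements on the series, on what has been measured and on what is new or still open speak of the compounds shown alone.

Compound 1, `CC1CCN(C(=S)SCc2ccc(C(=O)Nc3ccccc3N)cc2)CC1`, gives 46.8% in a functional assay on HeLa cells (Homo sapiens) for antiproliferative activity, read by CCK-8 assay, with a stated time of 72 h, tested at 2 uM; on this read-out lower numbers stand for a weaker effect and higher numbers for a stronger effect at the one concentration tested.
Compound 2, `CN(Cc1cccnc1)C(=S)SCc1ccc(C(=O)Nc2ccccc2N)cc1`, gives 16.4% in this assay.
Compound 3, `Nc1ccccc1NC(=O)c1ccc(CSC(=S)N2CCN(Cc3ccncc3)CC2)cc1`, gives 59.5% in this assay.

All three share one core and differ only in the group attached to the thiocarbonyl carbon. Compound 3 stands highest of the three numbers: compound 1 sits nearest but beyond the scatter below it, and compound 2 lies furthest below. Among the compounds with values here, the single measured step, a number 30.4 percentage points lower from compound 1 to compound 2 (beyond the scatter), shows that exchanging this group can move the read-out a great deal.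

Compound 4, `N#Cc1ccc(N2CCN(C(=S)SCc3ccc(C(=O)Nc4ccccc4N)cc3)CC2)cc1`, differs from compound 3 by 4-cyanophenyl in place of (pyridin-4-yl)methyl on an amine nitrogen in a ring. Within the data shown here, no measured step covers this kind of exchange: both compounds keep the six-membered non-aromatic ring with 2 nitrogen, and only the group on its amine nitrogen is swapped, so the measured step from compound 1 to compound 2 gives only a sense of how much such groups can matter, not a direction. The step of a number 9.5 percentage points lower from compound 3 to compound 4 (within the scatter) is therefore expected to be small and uncertain, leaning slightly downward. Compound 4 is expected to give about 50%, within a range from 25% to 72%.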

Compound 4, a percentage reported as inhibition, at one concentration (the size of the read-out at that concentration, not a potency): 71.6%
Compound 4: the middle estimate sits 21.6 percentage points below what was measured; measured number inside the range.
By their numbers in this assay, from the lowest: compound 2; then compound 1; then compound 3; then compound 4.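

In this assay, the step of a number 12.1 percentage points higher from compound 3 to compound 4 (beyond the scatter) shows that the group on the amine nitrogen of the six-membered non-aromatic ring is more than a place where the read-out merely holds: exchanging (pyridin-4-yl)methyl for 4-cyanophenyl here raises the number. The two groups have the same counts of hydrogen-bond donors and acceptors and neither has a net charge, so these counts do not separate them; what differs is an aromatic ring of carbon only with a nitrile in place of an aromatic ring with a hetero atom, and the loss of the methyl link. No measurement at hand gives a reason for this rise.

The compounds shown leave open what a plain phenyl group or a (4-cyanophenyl)methyl group on the same nitrogen would give, so the part played by the nitrile cannot be told apart from that of the missing methyl link. From the compounds shown here alone, the read-out is also taken at one concentration and is not a potency, so how compound 3 and compound 4 compare across a range of concentrations stays open.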